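A few compounds are considered here, and "the series" means these few. Any claim that something is new, unique, unknown or untested is made for them only; others in the source may bear on it.

Compound 2, with structure `COc1ccc(/C=C\C(=O)O)c(OCc2cn(-c3ccc(CO)cc3)nn2)c1CC=C(C)C`, has no result in a functional assay on A549 cells (Homo sapiens) for cytotoxicity, read by MTT assay, with a stated time of 24 h; a higher number here means a weaker inhibitor, a lower number a stronger inhibitor: in this assay compound 2 is recorded as "not determined" (no result reported), so no single number places it. The nearest measured relative is compound 1, `COc1ccc(-n2cc(COc3c(/C=C\C(=O)O)ccc(OC)c3CC=C(C)C)nn2)cc1`, which in this assay gives 10200 nM. The step from compound 2 leads to compound 3, `COc1cccc(-n2cc(COc3c(/C=C\C(=O)O)ccc(OC)c3CC=C(C)C)nn2)c1`, a compound not yet tested. The change between them is 3-methoxyphenyl in place of 4-(hydroxymethyl)phenyl on an aromatic nitrogen. Compound 3 has the same atoms as compound 1, joined differently, and the two differ only in where the methoxy group sits on the phenyl ring attached to the aromatic nitrogen. Compound 2 carries no number, so no step size can be computed, and the expectation for compound 3 rests on compound 1 alone, which gives 10200 nM. In this assay compound 3 is expected to give about 10000 nM, within a range from 4000 nM to 30000 nM, close to what compound 1 shows.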

Compound 3, half-maximal inhibitory concentration: 42700 nM
Compound 3: middle estimate off by 4.3-fold (0.63 log units), on the low side; the whole stated range lies below it.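

In this assay, moving the methoxy group on the phenyl ring attached to the aromatic nitrogen changes the result: 3-methoxyphenyl in place of 4-methoxyphenyl gives a 4.2-fold higher number from compound 1 to compound 3 (0.62 log units; beyond the scatter), a modest step but one beyond the scatter, toward weaker inhibition. This position therefore responds to where the methoxy group sits on that ring, even though the atoms stay the same, which compound 1 alone could not show. The step from compound 2 to compound 3 cannot be read, and nothing at hand accounts for the shift between compound 1 and compound 3.

As far as these compounds go, it remains open where the 4-(hydroxymethyl)phenyl of compound 2 would fall relative to the two methoxy isomers. Only one pair of isomers is shown, so it is also open whether an amine or a chlorine atom in place of the methoxy group would show a similar dependence on its place on the ring.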